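The source may report more compounds than this note shows. Statements on the series, on what has been measured and on what is new or still open speak of the compounds shown alone.

Three compounds share one core and differ only in the group on the aromatic ring. Compound 1 `CCN1C(=O)/C(=C/c2ccc(Cl)cc2)SC1=S` carries a chloro group; in an assay for inhibition of LL-diaminopimelate aminotransferase, chloroplastic (Arabidopsis thaliana) (on this read-out higher numbers stand for weaker inhibition and lower numbers for stronger inhibition), compound 1 gives 200000 nM. Compound 2 `CCN1C(=O)/C(=C/c2ccc(OC)cc2)SC1=S` carries a methoxy group instead. In this assay compound 2 gives > 200000 nM, which is a limit of the measurement and not a number. Compound 3 `CCN1C(=O)/C(=C/c2ccccc2)SC1=S` carries a hydrogen there. In this assay compound 3 gives > 200000 nM, again a limit and not a number. Compound 3 therefore stands at the edge of what the assay reports, and the steps of a number no lower from compound 1 to compound 3 (the limit leaves the size open) and a step that the two limits leave unreadable from compound 2 to compound 3 cannot be sized because the limit of > 200000 nM in this assay, at which 2 of the 3 values shown sit, hides the true values.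

Compound 4 `CCN1C(=O)/C(=C/c2ccccc2O)SC1=S` differs from compound 3 by hydroxy in place of hydrogen on an aromatic carbon. Among the measured compounds shown here, none of the measured steps, including a number no lower from compound 1 to compound 2 (the limit leaves the size open), brought any compound clearly away from the limit, so no step beyond the scatter is expected from this change either. The expected step is a number no higher from compound 3 to compound 4 (the limit leaves the size open). Compound 4 is accordingly estimated at 200000 nM, between 80000 nM and 500000 nM, with a strong chance that only a limit is again reported.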

Compound 4, half-maximal inhibitory concentration: > 200000 nM
Compound 4 gave a limit, no number (the forecaster's own chance of this, stated with the estimate: 70%); the middle value lies on the limit itself.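

Compound 3 and compound 4 both give only a limit in this assay, not a number, so no step between them can be read: the limit of > 200000 nM in this assay, at which 3 of the 4 values shown sit.

The compounds shown leave open how strongly compound 2, compound 3 and compound 4 truly inhibit, and whether any group on the aromatic ring moves a value clearly away from this limit.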